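The source may hold more compounds than are shown below. What is called first, only, known or untested is meant among the compounds shown, and "the series" means these compounds.

In a functional assay (aorta) with Oryctolagus cuniculus as the target (a higher number here means weaker binding, a lower number tighter binding), compound 1 `CCCc1nc2c(Cl)ccnc2n1Cc1ccc(-c2ccccc2C(=O)O)cc1` gives 7.94 nM as its dissociation constant, while compound 2 `Cc1ccnc2c1nc(C)n2Cc1ccc(-c2ccccc2C(=O)O)cc1` gives 50.1 nM on the same read-out. Compound 2 therefore holds the higher number of the two, which means the weaker binding, and its gap to compound 1 lies beyond the usual scatter of repeated measurements.

Compound 3 `Cc1ccnc2c1nc(C1CCC1)n2Cc1ccc(-c2ccccc2C(=O)O)cc1` differs from compound 2 in one place: cyclobutyl stands in place of methyl on an aromatic carbon, between two ring nitrogen atoms and next to the ring atom that bears a large group (cyclobutyl in place of methyl on an aromatic carbon). For the measured compounds named here, no measured pair of compounds differs in just one place, so this change has no direct precedent here. The expectation is a moderate step towards a lower number in this assay, beyond the scatter but with wide uncertainty. Going by the values given here, the value of compound 1 at 7.94 nM is the only guide to how low the number might go, and compound 3 is expected to land near it. The estimated change is a 3.3-fold lower number from compound 2 to compound 3 (0.52 log units; beyond the scatter). For compound 3 the estimated value is 15 nM, with an expected range from 4 nM to 55 nM.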

Compound 3, dissociation constant: 5.01 nM
Compound 3: middle estimate off by 3.0-fold (0.48 log units), on the high side; the measured number falls inside the stated range.
By their numbers in this assay, from the lowest: compounds 3 and 1 (each within the scatter of the next); then compound 2.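

In this assay, putting cyclobutyl in place of methyl on the aromatic carbon between two ring nitrogen atoms gives a 10-fold lower number from compound 2 to compound 3 (1.00 log units; beyond the scatter). For the compounds shown here, this is the first direct reading of a single change, as compound 1 and compound 2 differ in more than one place and their gap could not be assigned to any one group. It shows that this position, next to the ring atom that bears a large group, can carry a ring of four carbon atoms instead of a single carbon with a clear gain in binding rather than a loss, though nothing here gives a measured reason for that gain.

This single step cannot say whether the gain depends on the ring itself or simply on having more carbon atoms at this position, and a comparison of cyclopropyl, cyclopentyl and an open chain such as isobutyl on the same core would separate those readings. It also leaves open whether a group carrying a heteroatom, such as an ether or an amine, would be accepted at this position as well.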